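A few compounds are considered here, and "the series" means these few. Any claim that something is new, unique, unknown or untested is made for them only; others in the source may bear on it.

Of the compounds shown here, two built on the same shared core have so far been tested in an assay on HEK293 cells for inhibition of sodium-dependent dopamine transporter (Homo sapiens), read by scintillation counting, with stated times of 5 min and 1 min; on this read-out lower numbers stand for stronger inhibition and higher numbers for weaker inhibition. Compound 1 `Cc1cc(O)nc(C[S+]([O-])C(c2ccccc2)c2ccccc2)n1` gives 109000 nM in this assay, a weak result. Compound 2 `Cc1nnc(C[S+]([O-])C(c2ccccc2)c2ccccc2)s1` was reported as "not active" (no number reported) in this assay, with no number attached, so it cannot be placed on a scale against compound 1; all that the two results show is that compound 1 produced a measurable value while compound 2 did not. Compound 3 `[O-][S+](Cc1cc(Br)cs1)C(c1ccccc1)c1ccccc1` has not yet been measured. It differs from compound 2 in one place: 4-bromothiophen-2-yl in place of 5-methyl-1,3,4-thiadiazol-2-yl on a saturated chain carbon bound to a sulfur. Among the compounds with values here, no measured pair of compounds shows what this kind of change does in this assay, and compound 2 itself offers no number from which a step could be sized, so the direction and size of the step are open. The nearest point of reference is the weak value of compound 1. Compound 3 is expected to give about 25000 nM in this assay, with a plausible range from 3000 nM to 200000 nM, and it remains possible that this assay again reports no number for it.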

Compound 3, half-maximal inhibitory concentration: 13700 nM
Compound 3: the middle estimate sits 1.8-fold (0.26 log units) above what was measured, within the range that was stated.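

In this assay, within the data shown here, putting 4-bromothiophen-2-yl in place of 4-hydroxy-6-methylpyrimidin-2-yl on a saturated chain carbon bound to a sulfur gives an 8.0-fold lower number from compound 1 to compound 3 (0.90 log units; beyond the scatter), the first step at this position that can be sized, and it points towards stronger inhibition. Compound 2 carries no number, so the step from it to compound 3 cannot be read; the two results show only that 4-bromothiophen-2-yl gives a measurable value in the place where 5-methyl-1,3,4-thiadiazol-2-yl gave none. Nothing measured here accounts for this lower number.

The rings compared differ in both their hetero atoms and their outer groups, and the compounds shown do not separate the contribution of the bromine from that of the thiophene ring. On these data alone, a plain thiophen-2-yl, a chlorine in place of the bromine, or a longer chain carrying the same 4-bromothiophen-2-yl would each test one part of the change, and the size of any such step remains open.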